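The source may hold more compounds than are shown below. What is called first, only, known or untested is meant among the compounds shown, and "the series" means these compounds.

Measured in an ADME assay on NIH3T3 cells (Mus musculus) for cytotoxicity, read by colorimetric assay and sulforhodamine B assay, with a stated time of 96 h (a lower number here means a stronger inhibitor, a higher number a weaker inhibitor), so far:
- compound 1 `Oc1cccc(/C=C/c2cc(O)ccc2O)c1` gives 10500 nM
- compound 2 `COc1cc(F)c(/C=C/c2cc(O)ccc2O)cc1O` gives 21100 nM
- compound 3 `Oc1ccc(O)c(/C=C/c2ccc(O)c(O)c2)c1` gives > 30000 nM which is a limit and not a number

Compound 3 therefore stands at the limit of this assay and has no exact place among the three. Compound 4 `COc1ccc(/C=C/c2cc(O)ccc2O)cc1O` differs from compound 3 by one change, hydroxy to methoxy: methyl in place of hydrogen on an oxygen on an aromatic ring on an oxygen on an aromatic ring.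

Going by the values given here, one measured step bears on this. It is an at least 2.8-fold higher number from compound 1 to compound 3 (0.45 log units; beyond the scatter) and it brought in the hydroxy that carries the methyl in compound 4. Capping that hydroxy may undo part of this step, so a modest move toward a lower number is expected. Compound 2 also holds a methoxy and gives 21100 nM in support of that direction. The estimated change is an at least 1.5-fold lower number from compound 3 to compound 4 (0.19 log units; that floor lies within the scatter) and its true size stays loose while compound 3 has only a limit. For compound 4 the estimated value is 19000 nM with an expected range from 9000 nM to 40000 nM and a reading at the limit remains possible.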

Compound 4, half-maximal inhibitory concentration: > 30000 nM
Compound 4: no number, only a limit; the forecaster's own chance of this, stated with the estimate: 30%; at least 1.5-fold (0.19 log units) between middle value and limit.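

In this assay compound 4 gives > 30000 nM, which is a limit and not a number, so placing methyl on the oxygen did not bring the reading back within the assay's range, and the limit is now shared: the limit of > 30000 nM in this assay, at which 2 of the 4 values shown sit. With two limits, the step for methyl in place of hydrogen on an oxygen on an aromatic ring cannot be read. Adding a methoxy gives an at least 2.8-fold higher number from compound 1 to compound 4 (0.45 log units; beyond the scatter), while hydrogen in place of fluoro gives an at least 1.4-fold higher number from compound 2 to compound 4 (0.15 log units; that floor lies within the scatter), so the effect of that change is not resolved.

Going by these compounds, the true values of compound 3 and compound 4 remain open, and so does the size of the methyl step. On these data alone, it is also open whether a longer chain on that oxygen, or an amine in place of that hydroxy, would give a value within range.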